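Lengthening the chain of compound 3

The source may hold more compounds than are shown below. What is called first, only, known or untested is meant among the compounds shown, and "the series" means these compounds.

Three measured compounds share one core and differ in the group at the end of the chain: compound 1 `Cc1ccccc1-c1nc(CN2CCC(C(=O)NCCCN3CCCC(C(C)C)C3)CC2)c(C)o1`, compound 2 `Cc1ccccc1-c1nc(CN2CCC(C(=O)NCCCN3CCCC(CC(C)C)C3)CC2)c(C)o1` and compound 3 `Cc1ccccc1-c1nc(CN2CCC(C(=O)NCCN3C[C@H](C)C[C@H](C)C3)CC2)c(C)o1`. In an ADME assay on microsomes from liver (Rattus norvegicus) for metabolic stability, read by LC-MS, using NADPH, at 37 degrees C (a higher number here means that the compound lasts longer, a lower number that the compound disappears faster), compound 1 gives 0.323 h and compound 2 gives 0.0383 h. Compound 3 gives > 0.5 h, which is a limit of the assay and not a number.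

Compound 4 `Cc1ccccc1-c1nc(CN2CCC(C(=O)NCCCCN3C[C@H](C)C[C@H](C)C3)CC2)c(C)o1` alters compound 3 in one place: 2-(3,5-dimethylpiperidin-1-yl)ethyl in place of 3,5-dimethylpiperidin-1-yl on a saturated chain carbon, two bonds along the chain from an amide-type nitrogen. In words, 2-(3,5-dimethylpiperidin-1-yl)ethyl replaces 3,5-dimethylpiperidin-1-yl.

Two measured steps shrink the group at this same place. The first, an at least 1.5-fold higher number from compound 1 to compound 3 (0.18 log units; that floor lies within the scatter), has a floor within the scatter, while the second, an at least 13-fold higher number from compound 2 to compound 3 (1.11 log units; beyond the scatter), is large. A smaller enlargement of the group, an 8.4-fold lower number from compound 1 to compound 2 (0.93 log units; beyond the scatter), is modest but lies beyond the scatter.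

Enlarging the group of compound 3 should therefore lower the number in this assay, with compound 1 at 0.323 h as the closest guide in group size. The expected change is an at least 3.3-fold lower number from compound 3 to compound 4 (0.52 log units; beyond the scatter). For compound 4 the estimated half-life is 0.15 h, with an expected range from 0.04 h to 0.5 h.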

Compound 4, half-life: 0.2 h
Compound 4: middle estimate off by 1.3-fold (0.12 log units), on the low side; the measured number falls inside the stated range.
By their numbers in this assay, from the lowest: compound 2; then compounds 4 and 1 (each within the scatter of the next). At a limit, above all of these: compound 3.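

Going by these compounds alone, replacing 3,5-dimethylpiperidin-1-yl with 2-(3,5-dimethylpiperidin-1-yl)ethyl lengthens the chain and leaves the ring and its two methyl groups unchanged, which no earlier step did, and the result is an at least 2.5-fold lower number from compound 3 to compound 4 (0.39 log units; beyond the scatter) in the half-life. Compound 3 gives > 0.5 h, a limit of the assay and not a number, so this step is only a floor: the limit of > 0.5 h in this assay, at which 1 of the 4 values shown sits. Among the compounds with the longer chains, there is a 1.6-fold lower number from compound 1 to compound 4 (0.21 log units; within the scatter) and so no separation, whereas there is a 5.2-fold higher number from compound 2 to compound 4 (0.72 log units; beyond the scatter) and so the isobutyl compound stays apart.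

On these data alone, how far the half-life truly falls on lengthening stays open, since only a floor is available. Also open, as far as these compounds go, is how a propyl chain carrying the same dimethylpiperidine ring, or a chain longer than butyl, would behave.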